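The source may hold more compounds than are shown below. What is called first, only, known or untested is meant among the compounds shown, and "the series" means these compounds.

In an assay for inhibition of 6-phosphofructo-2-kinase/fructose-2,6-bisphosphatase 3 (Homo sapiens), read by ADP-Glo, with a stated time of 2 h (on this read-out lower numbers stand for stronger inhibition and higher numbers for weaker inhibition), compound 1 `CN(C)S(=O)(=O)c1ccccc1Nc1cc(-c2ccc3ccn(C)c3c2)c2nccnc2c1` gives 94 nM, the highest number among the three measured compounds. Compound 2 `Cn1ccc2ccc(-c3cc(Nc4ccccc4S(=O)(=O)N4CCOCC4)cc4nccnc34)cc21` gives 36 nM, and compound 3 `CN1CCCC(NS(=O)(=O)c2ccccc2Nc2cc(-c3ccc4ccn(C)c4c3)c3nccnc3c2)C1` gives 59 nM. Among the compounds with values here, the step with morpholin-4-yl in place of dimethylamino on a sulfonyl sulfur reads a 2.6-fold lower number from compound 1 to compound 2 (0.42 log units; beyond the scatter), the only one of the measured steps that clears the scatter. The step with (1-methylpiperidin-3-yl)amino in place of dimethylamino on a sulfonyl sulfur reads a 1.6-fold lower number from compound 1 to compound 3 (0.20 log units; within the scatter), so compound 1 and compound 3 cannot be told apart on these numbers.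

Compound 4 `CN1CCC(NS(=O)(=O)c2ccccc2Nc2cc(-c3ccc4ccn(C)c4c3)c3nccnc3c2)C1` has not yet been measured in this assay. It differs from compound 1 as follows: (1-methylpyrrolidin-3-yl)amino in place of dimethylamino on a sulfonyl sulfur. The closest measured precedent is the step to compound 3, whose entering group, (1-methylpiperidin-3-yl)amino, is the nearest relative of the (1-methylpyrrolidin-3-yl)amino entering here, and that step stayed within the scatter. The step to compound 2 shows that a change at this sulfonyl sulfur can move the number, but only modestly. On this basis the expected step is a 1.6-fold lower number from compound 1 to compound 4 (0.19 log units; within the scatter), not beyond the scatter. Compound 4 is estimated at 60 nM, with a range from 25 nM to 150 nM.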

Compound 4, half-maximal inhibitory concentration: 33 nM
Estimate against measurement, compound 4: 1.8-fold (0.26 log units) above; the range from low to high includes it.
By their numbers in this assay, from the lowest: compounds 4, 2, 3 and 1 (each within the scatter of the next, the first and the last beyond it).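

In this assay, the change from dimethylamino to (1-methylpyrrolidin-3-yl)amino on this sulfonyl sulfur gives a 2.8-fold lower number from compound 1 to compound 4 (0.45 log units; beyond the scatter), so a sulfonamide nitrogen carrying a ring can clear the scatter against dimethylamino, which the step to compound 3 did not do. That gain does not separate the ring sizes or the two larger groups: 1-methylpyrrolidin-3-yl in place of 1-methylpiperidin-3-yl gives a 1.8-fold lower number from compound 3 to compound 4 (0.25 log units; within the scatter), and (1-methylpyrrolidin-3-yl)amino in place of morpholin-4-yl gives a 1.1-fold lower number from compound 2 to compound 4 (0.04 log units; within the scatter), both within the scatter, so compound 4 cannot be told apart from compound 3 or compound 2. Nothing in the material at hand accounts for the size of the step from dimethylamino.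

The compounds shown leave open whether the ring itself matters, or whether an open chain such as 2-(dimethylamino)ethyl on the sulfonamide nitrogen would read like the 1-methylpyrrolidin-3-yl group. They also leave open what the methyl on the ring contributes, which a pyrrolidin-3-yl group without it, or a carboxylic acid on the same ring, would begin to test.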